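A chlorine shift at the cytotoxicity limit

The compounds below may be only part of what the source reports. "The series", "measured", "known", "first", "only" and "open" are said of these compounds alone.

In an ADME assay on BHK-21 cells (Mesocricetus auratus) for cytotoxicity, with a stated time of 3 days (on this read-out higher numbers stand for lower toxicity in this test and lower numbers for higher toxicity in this test), compound 1 `CC(Sc1nnc(-c2ccncc2)s1)C(=O)Nc1ccccc1Cl` gives > 50000 nM, which is a limit of the assay and not a number. Compound 2 `O=C(CCSc1nnc(-c2ccncc2)s1)NCc1ccccc1Cl` gives > 50000 nM, which is also a limit. Neither compound has an exact number, so the two cannot be ranked. Compound 3 `CC(Sc1nnc(-c2ccncc2)s1)C(=O)Nc1ccc(Cl)cc1` keeps the core of compound 1 and differs on an amide-type nitrogen: 4-chlorophenyl in place of 2-chlorophenyl on an amide-type nitrogen. Within the data shown here, no measured step guides this change, so the expectation rests on the limit of compound 1, > 50000 nM. The estimated change is a number no higher from compound 1 to compound 3 (the limit leaves the size open), nothing beyond the scatter. For compound 3, the estimate is 50000 nM, with an expected range of 20000 nM to 100000 nM.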

Compound 3, half-maximal cytotoxic concentration: > 50000 nM
Compound 3 gave a limit, no number; the forecaster's own chance of this, stated with the estimate: 80%; the middle value lies on the limit itself.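

Compound 1 and compound 3 both sit at a limit, not a number, so no step between them can be read in this assay: the limit of > 50000 nM in this assay, at which 3 of the 3 values shown sit.

Still open is the concentration at which any of these compounds harms the cells, and whether 4-chlorophenyl in place of 2-chlorophenyl changes it.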